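This account rests on a few compounds, and the source may have more. Where it says the series, first, only, none or still open, it means among the compounds named here.

Measured in an ADME assay on microsomes from liver (Mus musculus) for metabolic stability, read by LC-MS, using NADPH, with a stated time of 45 min, tested at 0.5 uM; on this read-out lower numbers stand for slow clearance and higher numbers for fast clearance:
compound 1, `O=C(CCCSc1nc2cc(Cl)ccc2o1)N1CCCC1`: 125 mL/min/g
compound 2, `CSc1nc2cc(Cl)ccc2o1`: > 46.1 mL/min/g
compound 3, `Cc1ccc2oc(SCCC(=O)N3CCCC3)nc2c1`: "not determined" (no result reported)

In this assay compound 1 gives 125 mL/min/g, a fast-clearance reading. For compound 2 the entry is a limit of the assay and not a number: in this assay compound 2 gives > 46.1 mL/min/g. Compound 2 thus stands at the limit of > 46.1 mL/min/g in this assay, at which 1 of the 3 values shown sits, and cannot be set in order against compound 1. Compound 3 returned no result in this assay. Going by the values given here, no pair of measured compounds differs in one place, so no measured step exists.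

Compound 4, `CN(C)C(=O)CCSc1nc2cc(Cl)ccc2o1`, differs from compound 2 by (dimethylcarbamoyl)methyl in place of hydrogen on a saturated chain carbon bound to a sulfur. Among the compounds with values here, with no measured step to lean on, the move from compound 2 to compound 4 in this assay is expected to fall within the scatter, or at most be a modest shift, direction uncertain. Compound 1, the only entry with a full number, reads 125 mL/min/g. Compound 4 is therefore expected to read 110 mL/min/g, within 45 mL/min/g to 260 mL/min/g. The expected step is a step that the limit leaves unreadable from compound 2 to compound 4.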

Compound 4, intrinsic clearance in a liver preparation (reported as CLH), per the amount of preparation that the assay uses: 41.8 mL/min/g
The estimate for compound 4 lay 2.6-fold (0.42 log units) above the measured number; the whole stated range lies above it.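

In this assay (dimethylcarbamoyl)methyl in place of hydrogen on a saturated chain carbon bound to a sulfur gives an at least 1.1-fold lower number from compound 2 to compound 4 (0.04 log units; that floor lies within the scatter) on the shared core. Going by these compounds alone, this is the only readable step; it points to the lower side of the read-out, but only its floor is fixed, and that floor does not go beyond the scatter. The step stays a floor because compound 2 carries a limit of the assay and not a number: the limit of > 46.1 mL/min/g in this assay, at which 1 of the 4 values shown sits.

From the compounds shown here alone, the true size of the step remains open, as does whether the lower reading holds for other groups at this carbon. A longer chain or a carboxylic acid in place of the dimethylamide end of the (dimethylcarbamoyl)methyl would test how much of the group the read-out follows.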